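The source may report more compounds than this note shows. Statements on the series, on what has been measured and on what is new or still open speak of the compounds shown alone.

Among the compounds with values here, compound 2 `C[C@H](CF)OC(=O)N1CCC(O[C@H]2CC[C@H](Oc3cnc(S(C)(=O)=O)cn3)CC2)CC1` gives 317 nM in a functional assay on isolated protein for agonist activity at Glucose-dependent insulinotropic receptor (Rattus norvegicus), read by HTRF and cAMP accumulation (on this read-out lower numbers stand for an effect already at smaller amounts and higher numbers for an effect only at larger amounts of compound), and holds the lowest of the two numbers measured so far. Compound 1 `CC(C)(C)OC(=O)N1CCC(O[C@H]2CC[C@H](Oc3ccc(S(C)(=O)=O)nn3)CC2)CC1` gives 1160 nM in this assay, a higher number than that of compound 2 by more than the usual scatter. Compound 3 `CC(F)Cc1nc(CN2CCC(O[C@H]3CC[C@H](Oc4cnc(S(C)(=O)=O)cn4)CC3)CC2)no1` has not yet been measured in this assay. It differs from compound 2 in one place: a group of 10 heavy atoms (6 carbon, 2 nitrogen, 1 oxygen, 1 fluorine; one five-membered aromatic ring with 3 hetero atoms) in place of a group of 7 heavy atoms (4 carbon, 2 oxygen, 1 fluorine; no ring), on an amine nitrogen in a ring. Within the data shown here, no pair of measured compounds differs by this change, so nothing measured speaks directly to it, and the expectation rests on little. Because compound 2 already gives 317 nM, the step of a 1.6-fold lower number from compound 2 to compound 3 (0.20 log units; within the scatter) is expected to be a modest one toward a lower number, with a range wide enough to admit no change beyond the scatter or a small shift the other way. On that basis compound 3 is expected to give about 200 nM in this assay, with a range from 60 nM to 700 nM.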

Compound 3, half-maximal effective concentration: 267 nM
Compound 3: the middle estimate sits 1.3-fold (0.13 log units) below what was measured, and the stated range covers the measured number.
By their numbers in this assay, from the lowest: compounds 3 and 2 (each within the scatter of the next); then compound 1.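

Within the data shown here, on the amine nitrogen in the six-membered ring, the (5-(2-fluoropropyl)-1,2,4-oxadiazol-3-yl)methyl group replaces a group with no ring and gives a 1.2-fold lower number from compound 2 to compound 3 (0.07 log units; within the scatter) in this assay, the first reading of a change at this position. The position therefore accepts a five-membered aromatic ring with 3 hetero atoms, on a group larger by the counts given, with no shift beyond the scatter. The group that leaves carries a double bond outside aromatic rings and the group that enters does not, so on this one pair that double bond is not needed for a number in this range, though nothing at hand explains why the two groups read alike.

This single step cannot separate the part played by the ring from that of the fluorine-bearing side chain, and a plain propyl chain on the same ring would be needed to speak to the fluorine. Nor does it show how far the position tolerates other kinds of group, such as a pyrimidine ring, a carboxylic acid or a longer chain.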